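From a methyl to a bromine on the outer ring

The compounds below may be only part of what the source reports. "The series", "measured", "known", "first", "only" and "open" are said of these compounds alone.

Compound 1, `CCCSc1nc(N/N=C/c2ccc(C)cc2)c2nnn(Cc3ccccc3)c2n1`, carries a 4-methylphenyl group at the end of its hydrazone arm. In a functional assay on MGC-803 cells (Homo sapiens) for antiproliferative activity, read by MTT assay, with a stated time of 72 h (a higher number here means a weaker inhibitor, a lower number a stronger inhibitor), compound 1 gives only a limit, > 64000 nM, not a number, so it stands at the edge of what the assay can report, (the limit of > 64000 nM in this assay, at which 1 of the 3 values shown sits). Two relatives sharing the same core were measured as numbers. Compound 2, `CCCSc1nc(N/N=C/c2cc(OC)c(OC)c(OC)c2)c2nnn(Cc3ccccc3)c2n1`, bears three methoxy groups on its outer ring and gives 9410 nM in this assay. Compound 3, `C#CCSc1nc(N/N=C(\C)c2ccccc2O)c2nnn(Cc3ccccc3)c2n1`, has a different side chain and a different outer ring, and gives 3820 nM in this assay.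

Compound 4, `CCCSc1nc(N/N=C/c2ccc(Br)cc2)c2nnn(Cc3ccccc3)c2n1`, differs from compound 1 in one place: bromo in place of methyl on an aromatic carbon. Going by the values given here, no measured pair here shows what such a swap does on this core, so the size of the step can only be guessed. Because compound 1 gives only > 64000 nM, compound 4 may again sit at the limit, or it may enter the measurable range as compound 2 and compound 3 do. The step of an at least 1.8-fold lower number from compound 1 to compound 4 (0.26 log units; that floor lies within the scatter) is expected to be modest, toward a somewhat stronger inhibitor, but with wide uncertainty. Compound 4 is therefore estimated at about 35000 nM, with a likely range from 9000 nM to 90000 nM.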

Compound 4, half-maximal inhibitory concentration: 34900 nM
Compound 4: the middle estimate sits 1.0-fold (0.00 log units) above what was measured, within the range that was stated.
By their numbers in this assay, from the lowest: compound 3; then compound 2; then compound 4. At a limit, above all of these: compound 1.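

Going by these compounds alone, with bromo in place of methyl on an aromatic carbon of the outer ring, compound 4 gives a measured number in this assay, so a change of one heavy atom at this position is enough to bring this series from the edge of the assay into its readable range, something the earlier compounds could not show. The step reads an at least 1.8-fold lower number from compound 1 to compound 4 (0.26 log units; that floor lies within the scatter), and it is only a floor: the real gap may be much larger, or it may be small enough to be lost in the ordinary spread of repeated measurements. That uncertainty comes from one side of the pair, since the entry for compound 1 is a limit of the assay and not a number: the limit of > 64000 nM in this assay, at which 1 of the 4 values shown sits.

As far as these compounds go, it remains open whether bromo is special here or whether other groups on the same carbon, such as chloro, an amine or a carboxylic acid, would also give a measurable value. From the compounds shown here alone, it is equally open how far the outcome depends on the rest of the molecule, for instance whether the same swap would behave alike with a longer chain on the sulfur.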